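This account rests on a few compounds, and the source may have more. Where it says the series, first, only, none or still open, it means among the compounds named here.

Measured compounds:

Compound 1, `CO[C@@H]1CC=C2N(c3ccccn3)C(=O)C[C@]2(c2ccccc2)O1` — in a functional assay on DU-145 cells (Homo sapiens) for cytotoxicity, read by sulforhodamine B assay, with a stated time of 48 h (a higher number here means a weaker inhibitor, a lower number a stronger inhibitor), compound 1 gives 8300 nM.
Compound 2, `CO[C@@H]1CC=C2N(c3c[nH]c4ccccc34)C(=O)C[C@]2(c2ccccc2)O1` — in this assay compound 2 gives 7330 nM.

Compound 2 has the lower of the two numbers, but the gap between them is only a 1.1-fold lower number from compound 1 to compound 2 (0.05 log units; within the scatter), so the two compounds cannot be told apart on this evidence; neither counts as the stronger one.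

Compound 3, `CO[C@@H]1CC=C2N(c3cc(Cl)cc(Cl)c3)C(=O)C[C@]2(c2ccccc2)O1`, has not yet been tested. It keeps the shared core of compound 2 and differs in one place: 3,5-dichlorophenyl in place of 1H-indol-3-yl on an amide-type nitrogen in a ring. Among the measured compounds shown here, the only measured step that bears on this change is the one from compound 1 to compound 2, where one aromatic group on the same ring nitrogen was exchanged for another and the number moved by a 1.1-fold lower number from compound 1 to compound 2 (0.05 log units; within the scatter), within the scatter. That single step suggests that the aromatic group on this nitrogen can be varied without a large shift in this assay, although a 3,5-dichlorophenyl group has not been tried here, so nothing beyond the scatter is expected in either direction. On that basis compound 3 is estimated at 7000 nM, with a likely range from 2500 nM to 20000 nM, a step of a 1.0-fold lower number from compound 2 to compound 3 (0.02 log units; within the scatter) from compound 2.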

Compound 3, half-maximal inhibitory concentration: 8170 nM
Compound 3: the middle estimate sits 1.2-fold (0.07 log units) below what was measured; measured number inside the range.
By their numbers in this assay, from the lowest: compounds 2, 3 and 1 (each within the scatter of the next).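

The new compound puts a different kind of group on the amide-type nitrogen in a ring: 3,5-dichlorophenyl, a six-membered aromatic ring of carbon only that carries chlorine and has no hydrogen-bond donor. In this assay the exchange for 1H-indol-3-yl gives a 1.1-fold higher number from compound 2 to compound 3 (0.05 log units; within the scatter) and the exchange for pyridin-2-yl gives a 1.0-fold lower number from compound 1 to compound 3 (0.01 log units; within the scatter) as its result, so the three groups on this nitrogen cannot be told apart, even though the hydrogen-bond donor of 1H-indol-3-yl is gone and chlorine has entered. Nothing available here explains why these numbers stay so close together.

All three groups shown at this position are aromatic rings, so it remains open whether an amine, a carboxylic acid or a longer carbon chain on the same nitrogen would move the number beyond the scatter. The phenyl group on the shared core is the same throughout, which leaves open whether replacing it with a small alkyl chain or a pyridine ring would change the number more than any exchange on the nitrogen has.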